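Piperidine to morpholine amide on a weak inhibitor

A few compounds are considered here, and "the series" means these few. Any claim that something is new, unique, unknown or untested is made for them only; others in the source may bear on it.

Measured in a functional assay on a cell-free system (Platelet, plasma, Homo sapiens) for inhibition, read by turbidimetry, with a stated time of 3 min; on this read-out higher numbers stand for weaker inhibition and lower numbers for stronger inhibition:
- compound 1 `COc1ccc(-n2nc(C(=O)N3CCCCC3)cc2-c2ccc(Cl)cc2)nn1` gives 41 nM
- compound 2 `COc1ccc(-c2onc(C(=O)N3CCCCC3)c2-c2ccc(Cl)cc2)cc1` gives 5030 nM

Of these two compounds, compound 2 has the higher number and so the weaker inhibition, and the gap to compound 1 lies beyond the scatter. Compound 3 `COc1ccc(-c2onc(C(=O)N3CCOCC3)c2-c2ccc(Cl)cc2)cc1` keeps the core of compound 2 and differs from it in one place (morpholin-4-yl in place of piperidin-1-yl on a carbonyl carbon), with morpholin-4-yl in place of piperidin-1-yl on a carbonyl carbon. Among the measured compounds shown here, no measured pair shows this exchange, so the expectation rests on the structural change alone. No step beyond the scatter is expected in this assay, and any shift should lean toward weaker inhibition (a 1.8-fold higher number from compound 2 to compound 3 (0.25 log units; within the scatter)). Compound 3 is estimated at a middle value (9000 nM), within an expected range (2500 nM to 30000 nM).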

Compound 3, half-maximal inhibitory concentration: 18400 nM
Beside the measured number, compound 3's estimate is 2.0-fold (0.31 log units) below it; measured number inside the range.
By their numbers in this assay, from the lowest: compound 1; then compound 2; then compound 3.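

Compound 1 and compound 2 differ in more than one place, so neither could isolate the amide group. In this assay, the exchange of piperidin-1-yl for morpholin-4-yl on a carbonyl carbon gives a 3.7-fold higher number from compound 2 to compound 3 (0.56 log units; beyond the scatter), showing that this place responds to the change, with weaker inhibition on an already weak inhibitor. No measurement at hand accounts for this step. On these data alone, whether the same exchange would weaken inhibition on the core of compound 1 remains open, as does the outcome with piperazin-1-yl or dimethylamino on that carbonyl carbon.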